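The compounds below may be only part of what the source reports. "The series", "measured", "known", "first", "only" and "open" are said of these compounds alone.

Three compounds have so far been measured in a functional assay for agonist activity at growth hormone secretagogue receptor type 1 (Homo sapiens), read by FLIPR; on this read-out lower numbers stand for smaller maximal responses and higher numbers for larger maximal responses:

Compound 1 `COc1ccc(N2C[C@@H](C)N[C@@H](C)C2)cc1NS(=O)(=O)c1ccc(-c2ccccn2)s1`: 1.1
Compound 2 `C[C@@H]1CN(c2ccc(F)c(NS(=O)(=O)c3ccc(-c4ccccn4)s3)c2)C[C@H](C)N1`: 0.8
Compound 3 `COc1cccc(-c2ccc(S(=O)(=O)Nc3cc(N4C[C@@H](C)N[C@@H](C)C4)ccc3OC)cc2)c1`: 1

On these numbers compound 3 stands between the other two, close to compound 1 and further from compound 2. Compound 4 `COc1ccc(N2C[C@@H](C)N[C@@H](C)C2)cc1NS(=O)(=O)c1ccc(-c2cncnc2)cc1` differs from compound 3 in one place: pyrimidin-5-yl in place of 3-methoxyphenyl on an aromatic carbon. Within the data shown here, the only measured step, a number 0.30 lower from compound 1 to compound 2 (beyond the scatter), concerns fluoro in place of methoxy and so does not bear directly on pyrimidin-5-yl in place of 3-methoxyphenyl; no measured pair shows that change. With all three compounds near full response, no step beyond the scatter is expected in this assay, and the estimated step of no change at the digits printed from compound 3 to compound 4 (within the scatter) is small. Compound 4 is therefore expected to give 1, within a range of 0.8 to 1.2.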

Compound 4, intrinsic activity: the largest response reached, as a fraction of the reference agonist's: 0.6
For compound 4 the middle estimate is 0.40 above the measured one; the whole stated range lies above it.
By their numbers in this assay, from the lowest: compound 4; then compound 2; then compounds 3 and 1 (each within the scatter of the next).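

In this assay, pyrimidin-5-yl in place of 3-methoxyphenyl, on an aromatic carbon para to a large group, gives a number 0.40 lower from compound 3 to compound 4 (beyond the scatter). Among these compounds, this is the first sign that the group at this position can change the maximal response, and not only the fluoro or methoxy group changed between compound 1 and compound 2. No measurement available here accounts for the drop. Going by these compounds, what remains open is whether a plain phenyl or a pyridin-3-yl at this position would keep the response near that of compound 3 or bring it down toward that of compound 4.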